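Swapping the aryl group on a protein disulfide-isomerase inhibitor

The compounds below may be only part of what the source reports. "The series", "measured", "known", "first", "only" and "open" are said of these compounds alone.

Compound 1 `Cc1ccnc(NC(c2ccccc2)c2ccc3cccnc3c2O)c1`: in an assay for inhibition of protein disulfide-isomerase (Homo sapiens), with a stated time of 1 h (a higher number here means a weaker inhibitor, a lower number a stronger inhibitor), compound 1 gives < 200 nM, a limit of the assay rather than a number.
Compound 2 `CCc1ccc(C(Nc2cc(C)ccn2)c2ccc3cccnc3c2O)cc1`: in this assay compound 2 gives 5390 nM.

Compound 2 thus holds the only number shown, the other value being a limit (the limit of < 200 nM in this assay, at which 1 of the 2 values shown sits). Going by the values given here, the one measured step, an at least 26-fold higher number from compound 1 to compound 2 (1.43 log units; beyond the scatter), came from ethyl in place of hydrogen on an aromatic carbon. Compound 3 `Cc1ccnc(NC(c2ccc3cccnc3c2O)c2c(Cl)cccc2Cl)c1` differs from compound 2 by 2,6-dichlorophenyl in place of 4-ethylphenyl on a saturated chain carbon bound to an aromatic carbon and a nitrogen on an aromatic ring. On these data alone, this removes the ethyl whose arrival gave an at least 26-fold higher number from compound 1 to compound 2 (1.43 log units; beyond the scatter), but the 2,6-dichlorophenyl itself is untested, so the expected step of a 3.6-fold lower number from compound 2 to compound 3 (0.56 log units; beyond the scatter) is a moderate gain in strength with wide uncertainty. Compound 3 is estimated at 1500 nM, between 300 nM and 8000 nM.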

Compound 3, half-maximal inhibitory concentration: > 40000 nM
Compound 3: a limit, no number; the forecaster's own chance of this, stated with the estimate: 10%; at least 26-fold (1.42 log units) between middle value and limit.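

At this position, on a saturated chain carbon bound to an aromatic carbon and a nitrogen on an aromatic ring, losing the ethyl did not bring strength back: the change gave an at least 7.4-fold higher number from compound 2 to compound 3 (0.87 log units; beyond the scatter), and measured against the plain phenyl the change gave an at least 200-fold higher number from compound 1 to compound 3 (2.30 log units; beyond the scatter). Among these three compounds, both substituted rings give a higher number than the plain phenyl. Compound 3 stands at a limit of the assay, so its true distance from the others stays unknown: the limit of > 40000 nM in this assay, at which 1 of the 3 values shown sits.

Left open is whether a single fluorine or a methoxy group on the phenyl ring would be accepted, and whether one chlorine would cost as much as two.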